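Swapping an Amide for a Sulfonyl on a Shared Core

The source may report more compounds than this note shows. Statements on the series, on what has been measured and on what is new or still open speak of the compounds shown alone.

Compound 1 `Cn1c(=O)c(C(=O)Nc2ccc(F)cc2)cc2cnc(Nc3ccc4[nH]ccc4c3)nc21` carries a (4-fluorophenyl)carbamoyl group on its shared core. In a functional assay on K562 cells (Homo sapiens) for inhibition, read by trypan blue exclusion, with a stated time of 72 h (on this read-out lower numbers stand for stronger inhibition and higher numbers for weaker inhibition), compound 1 gives 5000 nM, the lowest of the two numbers available. Within the data shown here, compound 2 `O=c1c(S(=O)(=O)c2ccc(F)cc2F)cc2cnc(Nc3ccc4[nH]ccc4c3)nc2n1CC1CCCC1` is the only other compound with a number; in this assay compound 2 gives 7000 nM, and the two values sit within the usual scatter of each other, so neither compound can be called the stronger inhibitor. Compound 3 `Cn1c(=O)c(S(=O)(=O)c2ccc(F)cc2N)cc2cnc(Nc3ccc4[nH]ccc4c3)nc21` has not yet been measured. It differs from compound 1 in one place: (2-amino-4-fluorophenyl)sulfonyl in place of (4-fluorophenyl)carbamoyl on an aromatic carbon. Among the measured compounds shown here, only two compounds have numbers, and no single-change step between measured compounds exists; nothing here shows how such a change moves the half-maximal inhibitory concentration. The expected step of no change at the digits printed from compound 1 to compound 3 (within the scatter) is therefore set within the scatter, in no particular direction. Compound 3 is estimated at 5000 nM, with a range from 1500 nM to 16000 nM.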

Compound 3, half-maximal inhibitory concentration: 2000 nM
Estimate against measurement, compound 3: 2.5-fold (0.40 log units) above, within the range that was stated.
By their numbers in this assay, from the lowest: compound 3; then compounds 1 and 2 (each within the scatter of the next).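

In this assay, placing (2-amino-4-fluorophenyl)sulfonyl in place of (4-fluorophenyl)carbamoyl on this aromatic carbon gives a 2.5-fold lower number from compound 1 to compound 3 (0.40 log units; beyond the scatter). Among these compounds, this is the first comparison here in which only one place differs, and it shows that the number at this position can respond to the group attached there, with the sulfonyl compound giving the lower number for this pair. No measurement is available to explain why the number moved.

Among the compounds shown here, the single step combines two differences, since the link to the phenyl ring changes from carbamoyl to sulfonyl and an amino group appears on that ring, so the share of each stays open. A plain (4-fluorophenyl)sulfonyl group, without the amine, or a (2-hydroxy-4-fluorophenyl)sulfonyl group carrying a hydroxyl in its place, would be needed to separate them.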